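The source may hold more compounds than are shown below. What is called first, only, known or untested is meant among the compounds shown, and "the series" means these compounds.

Three compounds that share one core have numbers in a functional assay on HeLa cells (Homo sapiens) for inhibition, with a stated time of 72 h; on this read-out lower numbers stand for stronger inhibition and higher numbers for weaker inhibition. Compound 1 (`NC1CCC(Nc2nc(NCc3ccc(-c4ccsc4)cc3)c3ncn(C4CCCC4)c3n2)CC1`) gives 220 nM, compound 2 (`NC1CCC(Nc2nc(NCc3ccc(-c4ccccc4)nc3)c3ncn(C4CCCC4)c3n2)CC1`) gives 114 nM, and compound 3 (`NC1CCC(Nc2nc(NCc3ccc(-c4cccc(F)c4)nc3)c3ncn(C4CCCC4)c3n2)CC1`) gives 36 nM. Compound 2 is second highest of these three numbers, but it cannot be told apart from its nearest neighbour: the first measured step is a 1.9-fold lower number from compound 1 to compound 2 (0.29 log units; within the scatter). The other measured step is larger, a 3.2-fold lower number from compound 2 to compound 3 (0.50 log units; beyond the scatter).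

The unmeasured compound 4 (`Nc1ccccc1CNc1nc(NC2CCC(N)CC2)nc2c1ncn2C1CCCC1`) departs from compound 2 by one change, (2-aminophenyl in place of 6-phenylpyridin-3-yl on a saturated chain carbon bound to a nitrogen on an aromatic ring). In words, 2-aminophenyl stands in place of 6-phenylpyridin-3-yl on a saturated chain carbon bound to a nitrogen on an aromatic ring.

The first step bears most directly, since it exchanges groups at this same place, yet both of its groups carry two rings. The second step shows that a single fluoro in place of hydrogen on an aromatic carbon can already matter. Among the compounds with values here, no measured compound has only one ring in this group, so the guide is loose. A rise in the number, modestly beyond the scatter, seems likeliest. The step expected is a 3.5-fold higher number from compound 2 to compound 4 (0.55 log units; beyond the scatter). For compound 4 the estimated value in this assay is 400 nM, with an expected range from 100 nM to 1600 nM.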

Compound 4, half-maximal inhibitory concentration: 1030 nM
For compound 4 the middle estimate is 2.6-fold (0.41 log units) below the measured one; low and high end bracket the measured number.
By their numbers in this assay, from the lowest: compound 3; then compounds 2 and 1 (each within the scatter of the next); then compound 4.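

In this assay, putting 2-aminophenyl at this place, on a saturated chain carbon bound to a nitrogen on an aromatic ring, gives a 9.0-fold higher number from compound 2 to compound 4 (0.96 log units; beyond the scatter) and, measured against the thiophene-bearing group, a 4.7-fold higher number from compound 1 to compound 4 (0.67 log units; beyond the scatter). The earlier compounds shown here had held two rings in this group, and the exchange between those two groups stayed within the scatter, so they could not show whether the position tolerates every exchange; compound 4, with one six-membered aromatic ring of carbon only in this group, shows that it does not, since here the number moves beyond the scatter against both neighbours. No measurement in hand gives a reason for this higher number.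

The compounds shown leave open whether the higher number goes with the loss of the second ring or with the amine on the ring that remains, a question that a plain phenyl or a 2-hydroxyphenyl at this place would help to separate. Going by these compounds, whether fluoro in place of hydrogen on the ring of compound 4 would bring a change like a 3.2-fold lower number from compound 2 to compound 3 (0.50 log units; beyond the scatter) also stays open.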